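The compounds below may be only part of what the source reports. "The series", "measured", "known", "first", "only" and "open" are said of these compounds alone.

Series notes. Two compounds carry numbers. Compound 1 `COc1cc2c(Oc3ccc(NC(=O)N/N=C/c4ccc(C(F)(F)F)cc4)cc3F)ccnc2cc1OCCCN1CCC(C)CC1` gives 1000 nM in a functional assay on MKN-45 cells (Homo sapiens) for cytotoxicity, read by MTT assay, with a stated time of 72 h; on this read-out higher numbers stand for weaker inhibition and lower numbers for stronger inhibition. Compound 2 `COc1cc2c(Oc3ccc(NC(=S)N/N=C/c4ccc(F)c(F)c4)cc3F)ccnc2cc1OCCCN1CCCCC1` gives 740 nM in this assay. Among the measured compounds shown here, compound 2 has the lower of the two numbers, but its nearest neighbour is compound 1 and the gap between the two values lies within the scatter, so no order between them is claimed; the two differ at several places at once and no single step between them is counted.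

The next compound, compound 3 `COc1cc2c(Oc3ccc(NC(=S)N/N=C/c4ccc(F)cc4Cl)cc3F)ccnc2cc1OCCCN1CCCCC1`, changes one place of compound 2: 2-chloro-4-fluorophenyl in place of 3,4-difluorophenyl on a carbon with a double bond to nitrogen. For the measured compounds named here, no counted step touches this part of the molecule, and the two measured compounds give no guide to what a halogen swap on this ring does. For the step from compound 2 to compound 3 in this assay a change within the scatter is expected, in no particular direction, so a 1.1-fold higher number from compound 2 to compound 3 (0.03 log units; within the scatter) is the estimated step. Compound 3 is therefore expected to give about 800 nM in this assay, with a range of 350 nM to 1800 nM.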

Compound 3, half-maximal inhibitory concentration: 820 nM
Compound 3: middle estimate off by 1.0-fold (0.01 log units), on the low side; the range from low to high includes it.
By their numbers in this assay, from the lowest: compounds 2, 3 and 1 (each within the scatter of the next).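

Among the compounds shown here, at this place, on a carbon with a double bond to nitrogen, 2-chloro-4-fluorophenyl in place of 3,4-difluorophenyl gives a 1.1-fold higher number from compound 2 to compound 3 (0.04 log units; within the scatter) in this assay, the first counted step. The two groups have the same heavy-atom count and neither carries a hydrogen-bond donor or acceptor; one fluorine gives way to one chlorine and the halogens are rearranged on the ring, and for this single pair the read-out does not resolve that exchange. Nothing available on these compounds bears on why the two values sit so close.

From the compounds shown here alone, whether a different kind of substituent on this ring, such as a methoxy group, a nitrile or a carboxylic acid, would carry the number beyond the scatter remains open, since one pair of halogen patterns says little about the wider tolerance of this place. For the compounds shown here, also open is what the carbonyl of compound 1 contributes against the thiocarbonyl of compound 2, as those two differ at several places at once and no single step separates them.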